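The source may report more compounds than this note shows. Statements on the series, on what has been measured and on what is new or still open speak of the compounds shown alone.

Measured so far in a functional assay on K562 cells (Homo sapiens) for cytotoxicity, read by MTT assay; on this read-out lower numbers stand for stronger inhibition and higher numbers for weaker inhibition:
- compound 1 `COc1ccc(/C=C/C(=O)c2ccc(OC)c3c2OC(C)(C)C=C3)cc1OC(=O)CCl` gives 400 nM
- compound 2 `COc1ccc(/C=C/C(=O)c2ccc(OC)c3c2OC(C)(C)C=C3)cc1OC(=O)C1CC1` gives 410 nM
- compound 3 `COc1ccc(/C=C/C(=O)c2ccc(OC)c3c2OC(C)(C)C=C3)cc1CS(C)(=O)=O` gives 9240 nM

Compound 3 stands highest of the three in this assay, at 9240 nM, and is the weakest so far. The next compound is compound 4 `COc1ccc(/C=C/C(=O)c2ccc(OC)c3c2OC(C)(C)C=C3)cc1OS(=O)(=O)c1ccc(C)cc1`. The change is ((4-methylphenyl)sulfonyl)oxy in place of (methylsulfonyl)methyl on an aromatic carbon, with ((4-methylphenyl)sulfonyl)oxy in place of (methylsulfonyl)methyl on an aromatic carbon.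

Among the compounds with values here, two measured steps bear on this: a 23-fold higher number from compound 1 to compound 3 (1.36 log units; beyond the scatter) and a 23-fold higher number from compound 2 to compound 3 (1.35 log units; beyond the scatter). Both are large, and both lead away from a group joined through oxygen. The change between those two carbonyl esters, a 1.0-fold higher number from compound 1 to compound 2 (0.01 log units; within the scatter), made no difference beyond the scatter. Within the data shown here, compound 4 restores an oxygen link at that carbon, but with a sulfonyl in place of a carbonyl, and no measured compound covers that group. A sizeable step to a lower number is therefore expected, probably short of the full return. The estimated step is a 6.2-fold lower number from compound 3 to compound 4 (0.79 log units; beyond the scatter). Compound 4 is expected at 1500 nM, with an estimated range from 350 nM to 6000 nM.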

Compound 4, half-maximal inhibitory concentration: 7850 nM
Compound 4: the middle estimate sits 5.2-fold (0.72 log units) below what was measured; measured number outside the range, above it.
By their numbers in this assay, from the lowest: compounds 1 and 2 (each within the scatter of the next); then compounds 4 and 3 (each within the scatter of the next).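

In this assay, an oxygen link at this aromatic carbon is not enough on its own to give the lower numbers of the carbonyl esters: a 1.2-fold lower number from compound 3 to compound 4 (0.07 log units; within the scatter) stays within the scatter, even though oxygen returns at that carbon. With the oxygen held in place, the group on it matters, as (4-methylphenyl)sulfonyl in place of cyclopropylcarbonyl gives a 19-fold higher number from compound 2 to compound 4 (1.28 log units; beyond the scatter) and in place of (chloromethyl)carbonyl gives a 20-fold higher number from compound 1 to compound 4 (1.29 log units; beyond the scatter), both large. Nothing available explains these steps.

Open, on these data alone, is whether the higher numbers follow the sulfonyl link, the 4-methylphenyl ring or both, a question that a methylsulfonyl group on the same oxygen could separate. Also open, as far as these compounds go, is how widely the carbonyl group tolerates change, for instance with a benzoyl or aminoacetyl group on that oxygen.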